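The source may report more compounds than this note shows. Statements on the series, on what has been measured and on what is new or still open speak of the compounds shown alone.

Compound 1 `CCCCCCNC(=O)n1c(N)nc2ccccc21`: 2.4 nM
Compound 2 `COc1nc2ccccc2n1C(=O)NCCCCc1ccccc1`: 13.9 nM
Compound 3 `O=C(NCCCCc1ccccc1)Nc1nc2ccccc2[nH]1`: limit > 10000 nM

Of the compounds shown here, three have been measured in an assay on HEK293 cells for inhibition of acid ceramidase (Homo sapiens), read by fluorescence, with stated times of 30 min and 1 h; on this read-out higher numbers stand for weaker inhibition and lower numbers for stronger inhibition. Compound 1 gives 2.4 nM. Compound 2 gives 13.9 nM, the higher of the two numbers on record, so compound 1 sits below it. For compound 3 the read-out in this assay is only a limit, (the limit of > 10000 nM in this assay, at which 1 of the 3 values shown sits), and not a number.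

Compound 4 `Cc1nc2ccccc2n1C(=O)NCCCCc1ccccc1` has not yet been measured. It is derived from compound 2 by a single change: methyl in place of methoxy on an aromatic carbon. Both compounds keep the shared core and the phenylbutyl chain on the carbamoyl nitrogen. Within the data shown here, no measured pair in the set differs in just this way, so there is no step to lean on; the expectation is a modest move in this assay, toward a somewhat higher number than compound 2, though a result within the scatter would not surprise.

On that basis compound 4 is estimated at 25 nM, with a range from 6 nM to 150 nM, which would mean an expected step of a 1.8-fold higher number from compound 2 to compound 4 (0.25 log units; within the scatter).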

Compound 4, half-maximal inhibitory concentration in the acid ceramidase assay: 1 nM
The estimate for compound 4 lay 25-fold (1.40 log units) above the measured number, and the stated range ends above it.
By their numbers in the acid ceramidase assay, from the lowest: compound 4; then compound 1; then compound 2. At a limit, above all of these: compound 3.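

At this position, an aromatic carbon between two ring nitrogen atoms, methyl in place of methoxy gives in the acid ceramidase assay a 14-fold lower number from compound 2 to compound 4 (1.14 log units; beyond the scatter), so a single small change on the shared core, with the phenylbutyl chain kept, moves the number well beyond the scatter. In a physicochemical assay for metabolic stability, read by HPLC, in phosphate buffer, at pH 7.4, tested at 10 uM (a higher number here means that the compound lasts longer, a lower number that the compound disappears faster), compound 2 gives > 2 h, which is a limit of the assay and not a number. In the physicochemical assay compound 4 gives 0.117 h, so the change that strengthens inhibition also goes with a compound that disappears faster.

Going by these compounds, whether an ethyl group, a chlorine atom or an amine at this position would behave like methyl or like methoxy stays open. Also open, on these data alone, is whether any group there can combine the low number in the acid ceramidase assay with the longer half-life in the physicochemical assay.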